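The source may report more compounds than this note shows. Statements on the series, on what has been measured and on what is new or still open speak of the compounds shown alone.

Among the compounds with values here, compound 2 `COc1ccc(-c2csc(Cn3ccnc3)c2)cc1` gives 13% in an assay for inhibition of steroid 17-alpha-hydroxylase/17,20 lyase (Homo sapiens), using NADPH, tested at 2 uM (on this read-out higher numbers stand for a stronger effect at the one concentration tested and lower numbers for a weaker effect), the lowest of the three numbers known. Compound 1 `COc1ccc(-c2csc(Cn3ccnc3)c2)cc1OC` gives 14% in this assay, and compound 3 `CCC(c1ccc(-c2ccsc2)cc1)n1ccnc1` gives 83%, far apart from the other two. The change from compound 2 to compound 4 `Fc1ccc(-c2csc(Cn3ccnc3)c2)cc1` is fluoro in place of methoxy on an aromatic carbon. Within the data shown here, the only measured step touching the same spot is a number 1 percentage points lower from compound 1 to compound 2 (within the scatter), in which the methoxy was also removed, so the number hardly moved there. Since there is no measured case of fluoro in this assay, the expectation rests on that step alone: compound 4 is expected to move by no change at the digits printed from compound 2 to compound 4 (within the scatter), nothing beyond the scatter. Compound 4 is therefore estimated at 13%, in the range 3% to 25%.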

Compound 4, a percentage reported as inhibition, at one concentration (the size of the read-out at that concentration, not a potency): 20%
Compound 4: middle estimate off by 7 percentage points, on the low side; measured number inside the range.
By their numbers in this assay, from the lowest: compounds 2, 1 and 4 (each within the scatter of the next); then compound 3.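

The step of a number 7 percentage points higher from compound 2 to compound 4 (within the scatter) shows that this position, para to a large group, tolerates fluoro in place of methoxy in this assay. The swap takes away a carbon and the oxygen, with its hydrogen-bond acceptor, yet the number stays within the scatter, so at this level of effect the read-out does not depend on the methoxy. Nothing available explains this result. On these data alone, whether an amine, a carboxylic acid or a longer chain at this position would move the number beyond the scatter remains open.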